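Working notes: cytotoxicity across a three-compound set

A few compounds are considered here, and "the series" means these few. Any claim that something is new, unique, unknown or untested is made for them only; others in the source may bear on it.

Measured so far, in an ADME assay on Vero cells (Chlorocebus sabaeus) for cytotoxicity, read by MTT assay, with a stated time of 48 h; a lower number here means a stronger inhibitor, a higher number a weaker inhibitor:
Compound 1 `COc1ccc(CNc2nc(=O)c3cc(C(F)(F)F)cc([N+](=O)[O-])c3o2)cc1OC` gives 29.2 ug/mL.
Compound 2 `CN(Cc1ccc2c(c1)OCCO2)c1cc(=O)c2cc(C(F)(F)F)cc([N+](=O)[O-])c2s1` gives only a limit, > 64 ug/mL, not a number.
Compound 3 `COc1ccc(CN(C)c2nc(=O)c3cc(C(F)(F)F)cc([N+](=O)[O-])c3o2)cc1OC` gives 9.46 ug/mL.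

One step is measured: a 3.1-fold lower number from compound 1 to compound 3 (0.49 log units; beyond the scatter), a methyl in place of hydrogen on a nitrogen on an aromatic ring. Compound 2 stands apart in that it sits at the limit of > 64 ug/mL in this assay, at which 1 of the 3 values shown sits; no number is known for it.

Compound 4 `CN(Cc1ccccc1)c1cc(=O)c2cc(C(F)(F)F)cc([N+](=O)[O-])c2s1` differs from compound 2 in one place: phenyl in place of 2,3-dihydro-1,4-benzodioxin-6-yl on a saturated chain carbon bound to a nitrogen on an aromatic ring. For the measured compounds named here, no measured step bears on this change, since the single measured step concerns the nitrogen substituent and not the group on the saturated chain carbon. The expected step of a number no higher from compound 2 to compound 4 (the limit leaves the size open) is therefore none beyond the scatter. Compound 4 is expected to give 64 ug/mL, with a range from 30 ug/mL to 150 ug/mL, and may again return only a limit.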

Compound 4, half-maximal inhibitory concentration: > 64 ug/mL
Compound 4: only a limit was reported; the forecaster's own chance of this, stated with the estimate: 55%; the middle value sits exactly at the limit.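

Compound 2 and compound 4 both return only a limit in this assay, so no step can be read between them: the limit of > 64 ug/mL in this assay, at which 2 of the 4 values shown sit.

On these data alone, whether phenyl or 2,3-dihydro-1,4-benzodioxin-6-yl on the saturated chain carbon gives the lower number in this assay stays open.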